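Glycine transporter 1 series: oxan-2-yl for pyridin-2-yl

The compounds below may be only part of what the source reports. "The series", "measured", "known", "first", "only" and "open" are said of these compounds alone.

Compound 1 `C[C@H](Oc1ccc(S(C)(=O)=O)cc1C(=O)N1Cc2ccccc2C1)C(F)(F)F` gives 2540 nM in an assay on CHO cells for inhibition of sodium- and chloride-dependent glycine transporter 1 (Homo sapiens), read by scintillation counting; a lower number here means that less compound is needed, a higher number that more compound is needed for the effect. Compound 2 `C[C@H](Oc1ccc(S(C)(=O)=O)cc1C(=O)N1Cc2ccc(-c3ccccn3)cc2C1)C(F)(F)F` gives 84 nM in this assay and stands lowest of the two numbers; the nearest is compound 1, with a 30-fold lower number from compound 1 to compound 2 (1.48 log units; beyond the scatter). Compound 3 `C[C@H](Oc1ccc(S(C)(=O)=O)cc1C(=O)N1Cc2ccc(C3CCCCO3)cc2C1)C(F)(F)F` differs from compound 2 by oxan-2-yl in place of pyridin-2-yl on an aromatic carbon. For the measured compounds named here, the only measured step that bears on this position is the one from compound 1 to compound 2, which introduced the pyridin-2-yl group and was large. Going by the values given here, no measured pair compares two different groups at this position, so the share of that gain carried by a non-aromatic six-membered ring is unknown. A step upward, moderate in size and beyond the scatter, is expected in this assay, that is a 4.8-fold higher number from compound 2 to compound 3 (0.68 log units; beyond the scatter). Compound 3 is therefore estimated at 400 nM, with a range from 120 nM to 1500 nM.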

Compound 3, half-maximal effective concentration: 205 nM
Estimate against measurement, compound 3: 2.0-fold (0.29 log units) above, within the range that was stated.
By their numbers in this assay, from the lowest: compound 2; then compound 3; then compound 1.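

In this assay the gain at this position does not depend on an aromatic ring: oxan-2-yl in place of hydrogen still gives a 12-fold lower number from compound 1 to compound 3 (1.09 log units; beyond the scatter) and so keeps much of what pyridin-2-yl brought. For the compounds shown here, the exchange of the two rings is not neutral, however, with a 2.4-fold higher number from compound 2 to compound 3 (0.39 log units; beyond the scatter) as the first direct comparison of two groups at this position, and pyridin-2-yl ahead of oxan-2-yl. Nothing shown here bears on what lies behind this difference.

From the compounds shown here alone, it remains open whether the ring hetero atom contributes at all, since both groups carry one; a cyclohexyl ring of carbon only would test this. A piperidin-2-yl ring, which brings an amine to the same place, or an open methoxyethyl chain would show how far the gain extends beyond these two rings.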